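Fluoro for Methoxy: Expected Antiproliferative Activity of Compound 4

The compounds below may be only part of what the source reports. "The series", "measured", "known", "first", "only" and "open" are said of these compounds alone.

Three compounds were measured in a functional assay on M21 cells (Homo sapiens) for antiproliferative activity, read by sulforhodamine B assay, with a stated time of 48 h; on this read-out higher numbers stand for weaker inhibition and lower numbers for stronger inhibition:
compound 1, `COc1ccc(OS(=O)(=O)c2ccc(N3CCN(C)C3=O)cc2)cc1`, gives > 100000 nM, which is a limit of the assay.
compound 2, `CN1CCN(c2ccc(S(=O)(=O)Oc3ccc(F)cc3)cc2)C1=O`, gives > 100000 nM, also a limit of the assay.
compound 3, `CCN1CCN(c2ccc(S(=O)(=O)Oc3cccc(OC)c3)cc2)C1=O`, gives 7000 nM.

Compound 3 is the only one of the three with a number rather than a limit in this assay. Compound 1 and compound 2 are related by a single change, (fluoro in place of methoxy on an aromatic carbon), and the step that the two limits leave unreadable from compound 1 to compound 2 cannot be sized because of the limit of > 100000 nM in this assay, at which 2 of the 3 values shown sit.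

Compound 4, `CCN1CCN(c2ccc(S(=O)(=O)Oc3cccc(F)c3)cc2)C1=O`, has not yet been measured in this assay. It is made from compound 3 by fluoro in place of methoxy on an aromatic carbon. This is the same kind of change as that from compound 1 to compound 2, but not the same: in compound 1 the methoxy sits para to a large group, in compound 3 meta to a large group. The difference between the core of compound 1 and the core of compound 3 is not broken down here.

For the measured compounds named here, since the one measured instance of this change is unreadable, the expectation for compound 4 rests only on the value of compound 3 in this assay. The step from compound 3 to compound 4 is expected to be a 1.4-fold higher number from compound 3 to compound 4 (0.15 log units; within the scatter). Compound 4 is therefore estimated at 10000 nM, within a range from 3000 nM to 40000 nM.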

Compound 4, half-maximal inhibitory concentration: 11000 nM
Estimate against measurement, compound 4: 1.1-fold (0.04 log units) below; measured number inside the range.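

In this assay, putting fluoro in place of methoxy on the core of compound 3 gives a 1.6-fold higher number from compound 3 to compound 4 (0.20 log units; within the scatter), so for 3-methoxyphenyl to 3-fluorophenyl on this core the read-out does not separate the two groups. For the compounds shown here, this does not show that the change carries from one core to another, as it is the only readable instance: the other instance of the same kind, on the core of compound 1, is a step that cannot be read, so there is no second size to set beside this one. That earlier pair gives no number for the change on its core, and its two values are limits of the assay, not numbers: the limit of > 100000 nM in this assay, at which 2 of the 4 values shown sit.

The compounds shown leave open whether another group on the aromatic carbon that carries the methoxy or the fluoro, such as an amine, a carboxylic acid or a nitrile, would give a step beyond the scatter in this assay. They also leave open what a longer chain, such as propyl or butyl, in the place of the ethyl of compound 3 and compound 4 would do to the number.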